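From 2-Ethylphenyl to 3,4-Dimethylphenyl on a Shared Core

The source may report more compounds than this note shows. Statements on the series, on what has been measured and on what is new or still open speak of the compounds shown alone.

In a functional assay on T-24 cells (Homo sapiens) for antiproliferative activity, read by MTT assay, with a stated time of 48 h (a lower number here means a stronger inhibitor, a higher number a weaker inhibitor), compound 1 (`CCOc1ccc(NC(=O)Nc2cccc(CNc3nccnc3Cl)c2)cc1`) gives 9080 nM, and compound 2 (`CCc1ccccc1NC(=O)Nc1cccc(CNc2nccnc2Cl)c1`) gives 8720 nM. These two numbers lie within the usual scatter of each other, so compound 2 stands level with compound 1.

The next compound, compound 3 (`Cc1ccc(NC(=O)Nc2cccc(CNc3nccnc3Cl)c2)cc1C`), keeps the shared core and alters one group: 3,4-dimethylphenyl in place of 2-ethylphenyl on an amide-type nitrogen. In words, 3,4-dimethylphenyl takes the place of 2-ethylphenyl on an amide-type nitrogen. The two groups have the same atoms, joined differently.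

For the measured compounds named here, only one measured step bears on this change, and it concerns the same amide-type nitrogen. In that step, 2-ethylphenyl replaces 4-ethoxyphenyl, giving a 1.0-fold lower number from compound 1 to compound 2 (0.02 log units; within the scatter), which is within the scatter. Going by the values given here, this is thin evidence, and no measured compound carries 3,4-dimethylphenyl. Even so, no shift beyond the scatter is expected in this assay. The expected step is a 1.1-fold lower number from compound 2 to compound 3 (0.04 log units; within the scatter). Compound 3 is estimated at 8000 nM, with an expected range of 3500 nM to 18000 nM.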

Compound 3, half-maximal inhibitory concentration: 8930 nM
Estimate against measurement, compound 3: 1.1-fold (0.05 log units) below, and the stated range covers the measured number.
By their numbers in this assay, from the lowest: compounds 2, 3 and 1 (each within the scatter of the next).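

In this assay, rearranging the same carbon atoms on the amide-type nitrogen, with 3,4-dimethylphenyl in place of 2-ethylphenyl, gives a 1.0-fold higher number from compound 2 to compound 3 (0.01 log units; within the scatter). For the compounds shown here, the earlier step changed the atoms of the group as well as their arrangement, so this is the first pair to isolate arrangement alone, and at this place, for these two groups, that arrangement makes no difference that can be told from scatter. The change from 4-ethoxyphenyl to 3,4-dimethylphenyl gives a 1.0-fold lower number from compound 1 to compound 3 (0.01 log units; within the scatter), so all three groups now stand level with one another, and nothing measured here explains why they read alike.

Level readings among three substituted phenyl groups say little about how far this place tolerates change, since each group tested so far keeps a six-membered aromatic ring of carbon on the nitrogen. Still open, going by these compounds, is whether a phenyl ring bearing an amine or a carboxylic acid, or a longer alkyl chain in place of the ring, would give a number beyond the scatter of these three.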